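Methoxycarbonyl replaces the ethylphenyl arm on the shared core

A few compounds are considered here, and "the series" means these few. Any claim that something is new, unique, unknown or untested is made for them only; others in the source may bear on it.

Three compounds on the shared core have numbers in a functional assay on PANC-1 cells (Homo sapiens) for cytotoxicity, read by MTT assay, with a stated time of 72 h; on this read-out lower numbers stand for stronger inhibition and higher numbers for weaker inhibition. Compound 1 `CCc1ccc(-c2ccc(NC3=CC(=O)c4ncncc4C3=O)cc2)cc1` gives 1200 nM in this assay. Compound 3 `COc1cc(NC2=CC(=O)c3ncncc3C2=O)cc(OC)c1OC` gives 800 nM, a number that sits within the scatter of compound 1. Compound 2 `Cc1ccc(-c2ccc(NC3=CC(=O)c4ncncc4C3=O)cc2F)cc1` gives 4800 nM, a higher number than compound 1 by more than the scatter, so compound 1 stands second highest of the three, close to compound 3 and well apart from compound 2.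

Compound 4 `COC(=O)c1ccc(NC2=CC(=O)c3ncncc3C2=O)cc1` is not yet measured in this assay. It differs from compound 1 as follows: methoxycarbonyl in place of 4-ethylphenyl on an aromatic carbon. Going by the values given here, no pair of measured compounds differing in one place is available, so the size of this step has no precedent. Among the compounds with values here, compound 3 shows that a single substituted aromatic ring on the amine can hold the number near that of compound 1, but the ester group has no counterpart here.

Compound 4 is expected to give 2000 nM in this assay, with a range from 600 nM to 7000 nM. The expected step from compound 1 to compound 4 is a 1.7-fold higher number from compound 1 to compound 4 (0.22 log units; within the scatter), a modest move toward a higher number, possibly not beyond the scatter.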

Compound 4, half-maximal inhibitory concentration: 1100 nM
The estimate for compound 4 lay 1.8-fold (0.26 log units) above the measured number, and the stated range covers the measured number.
By their numbers in this assay, from the lowest: compounds 3, 4 and 1 (each within the scatter of the next); then compound 2.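

In this assay, going by these compounds alone, methoxycarbonyl in place of 4-ethylphenyl gives a 1.1-fold lower number from compound 1 to compound 4 (0.04 log units; within the scatter), the first step that changes one place only. At this aromatic carbon, para to a large group, the number therefore holds when the six-membered aromatic ring of 4-ethylphenyl is lost and the hydrogen-bond acceptors of methoxycarbonyl enter, so a second aromatic ring on this arm is not needed to keep it. No measurement at hand bears on why the two groups read alike.

As far as these compounds go, whether a carboxylic acid, a primary amide or an amine on the same aromatic carbon would also keep the number in this assay remains open. This single step also leaves open whether a longer ester or a lone ethyl group would fit the same picture.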